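Moving a Ring Substituent in an Ecdysone Receptor Agonist Series

The source may report more compounds than this note shows. Statements on the series, on what has been measured and on what is new or still open speak of the compounds shown alone.

Of the compounds shown here, three sharing one core have been measured. In an assay on cells for agonist activity at ecdysone receptor (Bombyx mori), read by a luciferase reporter, with a stated time of 24 h (on this read-out higher numbers stand for an effect only at larger amounts of compound and lower numbers for an effect already at smaller amounts), compound 1 `CC(C)(C)N(NC(=O)c1ccccc1Br)C(=O)c1ccccc1Cl` gives 316 nM, compound 2 `CC(C)(C)N(NC(=O)c1cccc(C#N)c1)C(=O)c1ccccc1Cl` gives 955 nM, and compound 3 `Cc1cccc(C(=O)NN(C(=O)c2ccccc2Cl)C(C)(C)C)c1` gives 603 nM. Compound 3 stands second highest of the three numbers; the two steps ending at it, a 1.6-fold lower number from compound 2 to compound 3 (0.20 log units; within the scatter) and a 1.9-fold higher number from compound 1 to compound 3 (0.28 log units; within the scatter), both lie within the scatter, whereas the step of a 3.0-fold higher number from compound 1 to compound 2 (0.48 log units; beyond the scatter) is the only one beyond it. Compound 4 `CC(C)(C)N(NC(=O)c1ccc(Br)cc1)C(=O)c1ccccc1Cl` differs from compound 3 by 4-bromophenyl in place of 3-methylphenyl on a carbonyl carbon. Within the data shown here, no measured step mirrors this exchange, so in this assay the change is expected to give a step of a 1.0-fold lower number from compound 3 to compound 4 (0.00 log units; within the scatter), not beyond the scatter. Compound 4 is therefore estimated at 600 nM, within a range from 200 nM to 2000 nM.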

Compound 4, half-maximal effective concentration: 33.9 nM
Beside the measured number, compound 4's estimate is 18-fold (1.25 log units) above it, outside the stated range (below it).
By their numbers in this assay, from the lowest: compound 4; then compounds 1, 3 and 2 (each within the scatter of the next, the first and the last beyond it).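

A group change on this carbonyl carbon now has a large effect, with 4-bromophenyl giving an 18-fold lower number from compound 3 to compound 4 (1.25 log units; beyond the scatter) and a 28-fold lower number from compound 2 to compound 4 (1.45 log units; beyond the scatter). The bromine also counts by where it sits on the ring: 4-bromophenyl in place of 2-bromophenyl gives a 9.3-fold lower number from compound 1 to compound 4 (0.97 log units; beyond the scatter), and compound 4 has the lowest number of the four, beyond the scatter of each of the others. Nothing available explains this gain. What 4-methylphenyl or 4-aminophenyl would give on this carbonyl carbon remains open, so the compounds shown cannot separate the role of bromine from that of the ring position.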